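This account rests on a few compounds, and the source may have more. Where it says the series, first, only, none or still open, it means among the compounds named here.

Among the compounds with values here, compound 1 `NC(=O)/C=C/c1ccncc1-c1ccc2ccccc2c1` stands alone in this set as the one compound with a number: in a functional assay on HCT-116 cells (Homo sapiens) for inhibition, read by MTT assay, with a stated time of 72 h (on this read-out higher numbers stand for weaker inhibition of growth and lower numbers for stronger inhibition of growth), compound 1 gives 12100 nM. Two relatives carry no result. For compound 2 `Cn1ncc2cc(-c3cnccc3/C=C/C(=O)N3CCOCC3)ccc21` the entry in this assay reads "not determined" (no result reported), and for compound 3 `O=C(/C=C/c1ccncc1-c1ccc2[nH]ccc2c1)N1CCOCC1` it reads "not determined" (no result reported). Compound 4 `COC(=O)/C=C/c1ccncc1-c1ccc2ccccc2c1` has not yet been measured. It differs from compound 1 in a single place: methoxy in place of amino on a carbonyl carbon. Within the data shown here, no step between measured compounds exists to guide the estimate, and compound 1 is already a weak inhibitor on this read-out. The step is expected to be small, a 1.3-fold higher number from compound 1 to compound 4 (0.12 log units; within the scatter), lying within or only just beyond the scatter, if anything toward weaker inhibition. Compound 4 is expected to give 16000 nM in this assay, with a range from 5000 nM to 50000 nM.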

Compound 4, concentration for 50% growth inhibition: 350 nM
Beside the measured number, compound 4's estimate is 46-fold (1.66 log units) above it; the whole stated range lies above it.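

Within the data shown here, the group on this carbonyl carbon proves to matter far more than the single change in atoms might suggest: in this assay, methoxy in place of amino gives a 35-fold lower number from compound 1 to compound 4 (1.54 log units; beyond the scatter) on the shared core. Among these compounds, the earlier compounds offered no step, so this is the first sign that the read-out is sensitive at this place. Nothing measured here gives a reason for the step. From the compounds shown here alone, it remains open whether a carboxylic acid or a longer ethyl ester at this carbonyl carbon would keep the lower number.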